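The source may hold more compounds than are shown below. What is called first, only, known or untested is meant among the compounds shown, and "the series" means these compounds.

Two dihydropyrimidinone esters have been tested in an assay on membranes from CHO cells for displacement of a labelled ligand from adenosine receptor A1 (Homo sapiens), read by scintillation counting, with a stated time of 60 min, tested at 1 uM (on this read-out lower numbers stand for less inhibition and higher numbers for more inhibition at the one concentration tested (going by the name of the read-out)), so far. Compound 1 `CC1=C(C(=O)OCc2ccccc2)C(c2ccco2)NC(=O)N1` gives 36% in this assay. Compound 2 `COC(=O)C1=C(C)NC(=O)NC1c1ccoc1` gives 8% in this assay, the lowest of the two numbers, and its nearest neighbour, compound 1, lies beyond the scatter above it; the two structures differ in more than one place, so the pair shows only what the two values are. The next compound, compound 3 `CCCOC(=O)C1=C(C)NC(=O)NC1c1ccoc1`, differs from compound 2 by a single change: ethyl in place of hydrogen on a saturated chain carbon bound to an oxygen next to a carbonyl group. Among the measured compounds shown here, no measured pair isolates that change, so there is no direct guide to its size. On the lengthening of the ester, a small rise is expected, and the step of a number 9 percentage points higher from compound 2 to compound 3 (within the scatter) is estimated to stay near the scatter. Compound 3 is therefore expected to give about 17% in this assay, with a range from 4% to 34%.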

Compound 3, a percentage reported as inhibition, at one concentration (the size of the read-out at that concentration, not a potency): 50%
Estimate against measurement, compound 3: 33 percentage points below; the whole stated range lies below it.
By their numbers in this assay, from the lowest: compound 2; then compound 1; then compound 3.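

In this assay, among the compounds shown here, the change from methoxycarbonyl to propoxycarbonyl gives a number 42 percentage points higher from compound 2 to compound 3 (beyond the scatter) and is the first single change that can be read. It shows that this place, a saturated chain carbon bound to an oxygen next to a carbonyl group, is not silent: ethyl in place of hydrogen there moves the inhibition at the one concentration tested by far more than the usual scatter. Nothing available here accounts for the size of this step.

From the compounds shown here alone, with only the methoxy and propoxy esters compared directly, it remains open whether a butyl chain or a longer chain would extend the rise, hold it or reverse it. A branched isopropyl ester, or an amide in place of the ester, also remains untested among the compounds shown.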